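This account rests on a few compounds, and the source may have more. Where it says the series, first, only, none or still open, it means among the compounds named here.

Compound 1 `CCC(Oc1ccc(-n2cc(C(F)(F)F)cn2)cc1)c1ccc(C(=O)NCCC(=O)O)cc1` was examined in an assay on cells for displacement of a labelled ligand from Glucagon receptor (Homo sapiens), in the presence of a further agent that is not named here (a lower number here means a stronger inhibitor, a higher number a weaker inhibitor), where compound 1 gives 1400 nM. Compound 2 `CCCC(Oc1ccc(-n2cc(F)cn2)cc1)c1ccc(C(=O)NCCC(=O)O)cc1` gives 1700 nM in this assay, a number that lies within the usual scatter of the value for compound 1, so the two cannot be told apart. Compound 3 `O=C(O)CCNC(=O)c1ccc(C(Oc2ccc(-n3cc(C(F)(F)F)cn3)cc2)C2CC2)cc1` has not yet been measured. It differs from compound 1 in one place: cyclopropyl in place of ethyl on a saturated chain carbon bound to an aromatic carbon and an oxygen on an aromatic ring. Within the data shown here, nothing among the measured compounds shows what such a change does, so the step from compound 1 to compound 3 in this assay is expected to be small, a 1.2-fold lower number from compound 1 to compound 3 (0.07 log units; within the scatter), and not beyond the scatter. Compound 3 is therefore estimated at 1200 nM, with a range from 500 nM to 3000 nM.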

Compound 3, inhibition constant: 1300 nM
The estimate for compound 3 lay 1.1-fold (0.03 log units) below the measured number; the range from low to high includes it.
By their numbers in this assay, from the lowest: compounds 3, 1 and 2 (each within the scatter of the next).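

At the saturated chain carbon bound to an aromatic carbon and an oxygen on an aromatic ring, replacing ethyl with cyclopropyl adds a three-membered ring, yet this assay shows only a 1.1-fold lower number from compound 1 to compound 3 (0.03 log units; within the scatter) for this change. This position therefore accepts this particular ring in place of the ethyl chain with no change that can be told from the scatter. No measurement shown here offers an explanation for this result. Still open, on these data alone, is what a cyclobutyl ring, a longer chain or an amine would do at this carbon.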